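The source may report more compounds than this note shows. Statements on the series, on what has been measured and on what is new or still open speak of the compounds shown alone.

Compound 1, `C=C1CC[C@@H]2[C@](C)(CO)[C@H](O)CC[C@@]2(C)[C@@H]1/C=C/C1=C/C(=C/CCC)OC1=O`, was tested in an assay on isolated protein for inhibition of Maltase-glucoamylase (Homo sapiens), tested at 100 uM (a higher number here means more inhibition at the concentration tested (going by the name of the read-out), a lower number less inhibition), and gives 43.5%. Compound 2, `C=C1CC[C@@H]2[C@](C)(CO)[C@H](O)CC[C@@]2(C)[C@@H]1/C=C/C1=C/C(=C/c2ccc(Cl)cc2)OC1=O`, shares the same core and differs from compound 1 only in the group on the lactone side chain; in this assay compound 2 is recorded as "not active" (no number reported), and no single number stands behind that entry. Where compound 2 stands can therefore be said only in words: it did not show inhibition that the study chose to quantify, while compound 1 did.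

Compound 3, `C=C1CC[C@@H]2[C@](C)(CO)[C@H](O)CC[C@@]2(C)[C@@H]1/C=C/C1=C/C(=C/c2cccc(Br)c2)OC1=O`, is the next member and is not yet measured in this assay. Its change from compound 2 is 3-bromophenyl in place of 4-chlorophenyl on a double-bonded chain carbon bound to a double-bonded ring carbon. Among the compounds with values here, no measured step between compound 2 and compound 3 exists, and with compound 2 lacking a number, no size of step can be computed in this assay; the account can only state that the halogenated aryl group of compound 2 gave no reported inhibition and that compound 3 keeps a halogenated aryl group of the same size at the same place.

On that basis, compound 3 is expected to give about 10% in this assay, estimated to lie between 0% and 30%.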

Compound 3, a percentage reported as inhibition, at one concentration (the size of the read-out at that concentration, not a potency): 16.7%
The estimate for compound 3 lay 6.7 percentage points below the measured number; measured number inside the range.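

Compound 3 shows that an aryl group on a double-bonded chain carbon bound to a double-bonded ring carbon can still leave a measurable inhibition in this assay, which the entry for compound 2 alone did not show. It also gives the first size for replacing the chain with a halogenated aryl group: putting 3-bromophenyl in place of propyl gives a number 26.8 percentage points lower from compound 1 to compound 3 (beyond the scatter) and lies beyond the scatter. The step between 4-chlorophenyl and 3-bromophenyl cannot be read, as compound 2 has no number, and nothing available bears on what lies behind the lower number of compound 3.

The compounds shown leave open whether the drop from the propyl chain belongs to the aromatic ring itself or to its halogen, and whether the halogen's identity or its place on the ring separates compound 3 from compound 2. An unsubstituted phenyl group and a 3-chlorophenyl group at this place would address those two questions, while a longer chain such as hexyl would show whether the number for compound 1 moves with chain length.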